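Trifluoromethyl for Methyl on the Benzyl Group

The compounds below may be only part of what the source reports. "The series", "measured", "known", "first", "only" and "open" are said of these compounds alone.

Compound 1 `Cc1cc(N2CC[C@@H](C)[C@@H](N(C)c3ncnc4[nH]ccc34)C2)n2nc(SCc3ccccc3Br)nc2n1` reaches only a limit in a toxicity assay on GES1 cells (Homo sapiens) for inhibition, read by MTT assay, with a stated time of 72 h (on this read-out lower numbers stand for stronger inhibition and higher numbers for weaker inhibition), reported as > 100000 nM. Within the data shown here, compound 2 `Cc1ccc(CSc2nc3nc(C)cc(N4CC[C@@H](C)[C@@H](N(C)c5ncnc6[nH]ccc56)C4)n3n2)cc1`, which carries 4-methylphenyl in place of 2-bromophenyl on a saturated chain carbon bound to a sulfur, is the one compound with a number in this assay, and compound 2 gives 82500 nM. The step between them is an at least 1.2-fold lower number from compound 1 to compound 2 (0.08 log units; that floor lies within the scatter), a figure bounded by the limit of > 100000 nM in this assay, at which 1 of the 2 values shown sits. Compound 3 `Cc1cc(N2CC[C@@H](C)[C@@H](N(C)c3ncnc4[nH]ccc34)C2)n2nc(SCc3ccc(C(F)(F)F)cc3)nc2n1` differs from compound 2 by trifluoromethyl in place of methyl on an aromatic carbon. Among the measured compounds shown here, no measured step covers a change of this kind; the sole measured step rests at a floor that lies within the scatter, so it offers no direction. Compound 3 is therefore expected to sit close to compound 2, with an estimated step of a 1.0-fold lower number from compound 2 to compound 3 (0.01 log units; within the scatter). The estimate for compound 3 in this assay is 80000 nM, in a range from 30000 nM to 200000 nM, with a fair chance that only a limit is reported.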

Compound 3, half-maximal inhibitory concentration: 17300 nM
Estimate against measurement, compound 3: 4.6-fold (0.67 log units) above; the whole stated range lies above it.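

Among these compounds, on the aromatic carbon that holds methyl in compound 2, trifluoromethyl gives a 4.8-fold lower number from compound 2 to compound 3 (0.68 log units; beyond the scatter) in this assay, the first step here with two measured ends that clears the scatter and so the first sign that this place on the benzyl group bears on the read-out. Compound 3 thereby has the lowest number of the three compounds shown. Compound 1 stands at a limit, so an at least 5.7-fold lower number from compound 1 to compound 3 (0.76 log units; beyond the scatter) is only a floor: the limit of > 100000 nM in this assay, at which 1 of the 3 values shown sits.

As far as these compounds go, whether the drop belongs to trifluoromethyl alone, or would also come with chlorine, a methoxy group or a nitrile on the same carbon, stays open. This one pair also cannot say whether the change would read the same with a longer chain between the sulfur and the ring.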